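The compounds below may be only part of what the source reports. "The series", "measured", "known", "first", "only" and "open" are said of these compounds alone.

Of the compounds shown here, three built on a shared core have been tested in an ADME assay on MT2 cells (Homo sapiens) for cytotoxicity, read by MTT assay; a lower number here means that less compound is tolerated, a higher number that more compound is tolerated. Compound 1 `Fc1cccc(F)c1Cc1cnc(Nc2ccc(CCOc3ccncc3)cc2)o1` gives 11000 nM in this assay, the lowest of the three numbers, so it is the least tolerated of them. Compound 3 `Clc1cccc(Cl)c1Cc1nnc(Nc2ccc(COCc3ccccc3)cc2)o1` gives 84000 nM in this assay, and compound 2 `OCc1ccc(Nc2ncc(Cc3c(F)cccc3F)o2)cc1Cl` gives 90000 nM, both beyond the scatter above compound 1, so both are tolerated at higher concentrations.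

Compound 4 `CSCc1ccc(Nc2ncc(Cc3c(F)cccc3F)o2)cc1` has not yet been measured. It differs from compound 1 in one place: methylsulfanyl in place of ((pyridin-4-yl)oxy)methyl on a saturated chain carbon bound to an aromatic carbon. For the measured compounds named here, no pair of measured compounds differs in exactly one place, so no measured step shows what a change of this kind does in this assay. Compound 2 and compound 3, which carry different tails from compound 1 and are tolerated at higher numbers, differ from it in more than one place and give only a loose hint of direction. Compound 4 is therefore expected to be tolerated somewhat better than compound 1, with a step of a 2.3-fold higher number from compound 1 to compound 4 (0.36 log units; beyond the scatter) of modest size, though a result within the scatter would not be surprising. The estimated value for compound 4 in this assay is 25000 nM, within a range from 8000 nM to 90000 nM.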

Compound 4, half-maximal cytotoxic concentration: > 100000 nM
Compound 4: only a limit was reported; the forecaster's own chance of this, stated with the estimate: 20%; middle value at least 4.0-fold (0.60 log units) away from the limit.
By their numbers in this assay, from the lowest: compound 1; then compounds 3 and 2 (each within the scatter of the next). At a limit, above all of these: compound 4.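

In this assay, for the compounds shown here, the change from 2-((pyridin-4-yl)oxy)ethyl to (methylsulfanyl)methyl is the first change in a single place that can be read, and it gives an at least 9.0-fold higher number from compound 1 to compound 4 (0.95 log units; beyond the scatter). Compound 4 gives > 100000 nM, which is a limit of the assay and not a number: the limit of > 100000 nM in this assay, at which 1 of the 4 values shown sits. The earlier compounds shown here differed from one another in more than one place, whereas this step ties a clear rise in the tolerated concentration to this one position, on a saturated chain carbon bound to an aromatic carbon, where a group of 8 heavy atoms with a six-membered aromatic ring gives way to one of 2 heavy atoms with no ring.

This single step cannot separate the loss of the ring from the loss of the ether oxygen, the shortening of the group or the arrival of sulfur. From the compounds shown here alone, it also remains open whether a methoxy group, an amine or a longer chain carrying the same sulfur at this position would be tolerated as well as the methylsulfanyl group of compound 4.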